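The source may hold more compounds than are shown below. What is called first, only, known or untested is meant among the compounds shown, and "the series" means these compounds.

Measured in a functional assay on MCF7 cells (Homo sapiens) for antiproliferative activity, read by MTT assay, with a stated time of 48 h; a lower number here means a stronger inhibitor, a higher number a weaker inhibitor:
Compound 1 `CCn1c(C(=O)NCCCN(C)C)ccc1C(CC)(CC)c1ccc(OCCC(O)(CC)CC)c(C)c1` gives 3350 nM.
Compound 2 `CCn1c(C(=O)NCC#N)ccc1C(CC)(CC)c1ccc(OCCC(O)(CC)CC)c(C)c1` gives only a limit, > 50000 nM.
Compound 3 `C=CCN(C)C(=O)c1ccc(C(CC)(CC)c2ccc(OCCC(O)(CC)CC)c(C)c2)n1CC` likewise gives only a limit, > 50000 nM.

Among the compounds with values here, compound 1 holds the only real number in this assay; the other two entries are limits, as the limit of > 50000 nM in this assay, at which 2 of the 3 values shown sit, records. Compound 4 `CCn1c(C(=O)NC(CC(=O)O)C(=O)OC)ccc1C(CC)(CC)c1ccc(OCCC(O)(CC)CC)c(C)c1` is yet to be tested; it differs from compound 1 in that (a group of 9 heavy atoms (5 carbon, 4 oxygen; no ring) in place of a group of 6 heavy atoms (5 carbon, 1 nitrogen; no ring), on an amide-type nitrogen). Two measured steps alter the same amide substituent: an at least 14-fold higher number from compound 1 to compound 2 (1.17 log units; beyond the scatter) and an at least 14-fold higher number from compound 1 to compound 3 (1.17 log units; beyond the scatter), both large and both ending at the limit. Compound 4 also gives up the 3-(dimethylamino)propyl group, so a large rise in the number is expected, with a fair chance that compound 4 again returns only a limit. For compound 4 the expected value is 40000 nM, between 10000 nM and 150000 nM, meaning a 12-fold higher number from compound 1 to compound 4 (1.08 log units; beyond the scatter).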

Compound 4, half-maximal inhibitory concentration: 10200 nM
For compound 4 the middle estimate is 3.9-fold (0.59 log units) above the measured one; low and high end bracket the measured number.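

In this assay, the amide-type nitrogen can lose the 3-(dimethylamino)propyl group without the value reaching the limit, the change giving a 3.0-fold higher number from compound 1 to compound 4 (0.48 log units; beyond the scatter). The new group also stands clear of the other two amides, with an at least 4.9-fold lower number from compound 2 to compound 4 (0.69 log units; beyond the scatter) and an at least 4.9-fold lower number from compound 3 to compound 4 (0.69 log units; beyond the scatter). Both of these steps start from a limit and so give only a bound: the limit of > 50000 nM in this assay, at which 2 of the 4 values shown sit.

The compounds shown do not separate the contribution of the carboxylic acid in compound 4 from that of its methyl ester. They also leave open how a longer amine chain on this nitrogen would compare with compound 1.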